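The source may hold more compounds than are shown below. What is called first, only, known or untested is meant among the compounds shown, and "the series" means these compounds.

Working notes on the series

compound 1 `CCC(=O)N(c1ccc(Cl)cc1)C1CCCC1N(C)C` gives 3 mg/kg
compound 2 `CCC(=O)N(c1ccc(Cl)c(C)c1)C1CCCC1N(C)C` gives 2 mg/kg

Among the measured compounds shown here, in a functional assay on the whole organism for positive allosteric modulation, with Mus musculus as the target (a higher number here means that more compound is needed for the effect, a lower number that less compound is needed), compound 1, at 3 mg/kg, stands within the scatter of compound 2, its only measured neighbour, so the two are not separated.

Compound 3 `CCC(=O)N(c1ccc([N+](=O)[O-])cc1)C1CCCC1N(C)C` is not yet measured. It keeps the core of compound 1 and differs as follows: nitro in place of chloro on an aromatic carbon. The chloro is replaced by nitro on an aromatic carbon, para to a large group.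

For the measured compounds named here, one measured step bears on this, and only indirectly, as it is a different change on a different aromatic carbon: a 1.5-fold lower number from compound 1 to compound 2 (0.18 log units; within the scatter). Going by the values given here, no measured step replaces the chloro itself, so no direction can be argued from the data. A step beyond the scatter is therefore not expected in this assay, though the uncertainty is wide.

The expected step is a 1.3-fold higher number from compound 1 to compound 3 (0.12 log units; within the scatter).

For compound 3 the estimate is 4 mg/kg, with an expected range from 1 mg/kg to 15 mg/kg.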

Compound 3, dose for half-maximal effect: 20 mg/kg
Compound 3: the middle estimate sits 5.0-fold (0.70 log units) below what was measured; the whole stated range lies below it.
By their numbers in this assay, from the lowest: compounds 2 and 1 (each within the scatter of the next); then compound 3.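

Nitro in place of chloro on the aromatic carbon para to a large group gives the only step among these compounds that lies beyond the scatter: a 6.7-fold higher number from compound 1 to compound 3 (0.82 log units; beyond the scatter) in this assay. Among the compounds shown here, the earlier comparison, a methyl on a different aromatic carbon, showed only a 1.5-fold lower number from compound 1 to compound 2 (0.18 log units; within the scatter), so this is the first sign that the series responds to a change on an aromatic carbon, and that the chloro position does not take every group alike. No measured data on the properties of these compounds bear on the size of this step, and its cause stays unassigned.

As far as these compounds go, whether an amine, a methoxy or a nitrile on the same carbon would sit close to compound 1 or close to compound 3 remains open. Also open, from the compounds shown here alone, is whether the methyl of compound 2 would leave the step from chloro to nitro unchanged if the two changes were combined.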